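From 3,5-dichlorophenyl to pyridin-3-yl in compound 4

A few compounds are considered here, and "the series" means these few. Any claim that something is new, unique, unknown or untested is made for them only; others in the source may bear on it.

Three related compounds have been tested in an ADME assay on MRC5 cells (Homo sapiens) for cytotoxicity, read by fluorescence and resazurin assay, with a stated time of 3 days; a lower number here means a stronger inhibitor, a higher number a weaker inhibitor. Compound 1 `Cc1cn(C2CCN(Cc3cccc(Oc4ccccc4)n3)CC2)c(=O)[nH]c1=O` gives > 64000 nM, which is a limit of the assay and not a number. Compound 3 `Cc1cn(C2CCN(Cc3cc(Oc4cccc(Cl)c4)ccn3)CC2)c(=O)[nH]c1=O` gives > 64000 nM, again a limit and not a number. For the measured compounds named here, compound 2 `Cc1cn(C2CCN(Cc3cccc(Oc4cc(Cl)cc(Cl)c4)c3)CC2)c(=O)[nH]c1=O` gives 6730 nM, the only actual number among the three.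

Compound 4 `Cc1cn(C2CCN(Cc3cccc(Oc4cccnc4)c3)CC2)c(=O)[nH]c1=O` keeps the shared core of compound 2 and changes one group: pyridin-3-yl in place of 3,5-dichlorophenyl on an oxygen on an aromatic ring. In words, pyridin-3-yl stands in place of 3,5-dichlorophenyl on an oxygen on an aromatic ring. Going by the values given here, no pair of measured compounds shows this change on its own, so its size can only be estimated. Among the compounds with values here, compound 2, at 6730 nM, is the only compound carrying the 3,5-dichlorophenyl group and the only one giving a number. The expected step of a 6.7-fold higher number from compound 2 to compound 4 (0.83 log units; beyond the scatter) therefore runs towards a higher number, meaning a weaker inhibitor, and the result may be only a limit. For compound 4 the estimated value is 45000 nM, with an expected range from 18000 nM to 64000 nM.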

Compound 4, half-maximal inhibitory concentration: > 64000 nM
Compound 4: no number, only a limit; the forecaster's own chance of this, stated with the estimate: 60%; middle value at least 1.4-fold (0.15 log units) away from the limit.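

For the compounds shown here, on an oxygen on an aromatic ring, pyridin-3-yl in place of 3,5-dichlorophenyl gives the first step with a readable size in this assay, an at least 9.5-fold higher number from compound 2 to compound 4 (0.97 log units; beyond the scatter). Going by these compounds alone, compound 4 gives > 64000 nM, which is a limit of the assay and not a number, so compound 2 remains the only compound here with an actual number. The true step may be larger than the one printed, because the readings stop at a ceiling: the limit of > 64000 nM in this assay, at which 3 of the 4 values shown sit.

The compounds shown do not separate the loss of the two chlorine atoms from the entry of the ring nitrogen, as none on the core of compound 2 has one change without the other. On these data alone, how an amine or a carboxylic acid on this ring would read in this assay also remains open.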